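Methyl in Place of Chloro: Compound 3 Awaits Measurement

The compounds below may be only part of what the source reports. "The series", "measured", "known", "first", "only" and "open" are said of these compounds alone.

In an ADME assay on HEK293 cells (Homo sapiens) for cytotoxicity, read by MTT assay, with a stated time of 48 h (a lower number here means a stronger inhibitor, a higher number a weaker inhibitor), compound 1 (`C=C1CCC[C@]2(C)CCC(c3cn(-c4ccc(C(C)=O)cc4)nn3)=CC[C@@]12C`) gives 520000 nM and compound 2 (`C=C1CCC[C@]2(C)CCC(c3cn(-c4ccc(Cl)cc4)nn3)=CC[C@@]12C`) gives 609000 nM so the two stand level, within the scatter of each other. Compound 2 therefore has only compound 1 as a neighbour on these numbers, and neither can be ranked above the other. Compound 3 (`C=C1CCC[C@]2(C)CCC(c3cn(-c4ccc(C)cc4)nn3)=CC[C@@]12C`) has not yet been measured. It differs from compound 2 by methyl in place of chloro on an aromatic carbon and this is methyl in place of chloro on an aromatic carbon, the change from 4-chlorophenyl to 4-methylphenyl. For the measured compounds named here, only one measured step bears on it: chloro in place of acetyl on an aromatic carbon, which gave a 1.2-fold higher number from compound 1 to compound 2 (0.07 log units; within the scatter) and so moved nothing beyond the scatter. With that single step as the guide, no step beyond the scatter is expected in this assay for the new exchange, though one step is thin evidence. The estimated step is a 1.1-fold lower number from compound 2 to compound 3 (0.03 log units; within the scatter) on this reading. For compound 3 the expected value is 570000 nM with an estimated range from 350000 nM to 900000 nM until the measurement is made.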

Compound 3, half-maximal inhibitory concentration: 524000 nM
For compound 3 the middle estimate is 1.1-fold (0.04 log units) above the measured one; the range from low to high includes it.
By their numbers in this assay, from the lowest: compounds 1, 3 and 2 (each within the scatter of the next).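

In this assay, the place on the aromatic carbon para to a large group now carries three different groups, and no exchange among them leaves the scatter: methyl in place of chloro gives a 1.2-fold lower number from compound 2 to compound 3 (0.07 log units; within the scatter) and is read alongside methyl in place of acetyl, which gives a 1.0-fold higher number from compound 1 to compound 3 (0.00 log units; within the scatter) and so closes the set of three pairs. Until now this place rested on one exchange, between acetyl and chloro, whereas the two new steps show that 4-methylphenyl also stands level with both 4-chlorophenyl and the acetyl-bearing ring, so that compounds 1, 2 and 3 cannot be ranked against one another in this assay. Nothing in the material shown accounts for this flat result, and no supporting measurement accompanies it.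

The three compounds leave open whether any group at this place can move the number beyond the scatter, for instance an amine, a carboxylic acid, a hydroxyl or a longer chain such as butyl. They also leave open how the number responds to a change elsewhere, whether on the triazole-linked side or in the shared core, since all three keep that core unchanged.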